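A few compounds are considered here, and "the series" means these few. Any claim that something is new, unique, unknown or untested is made for them only; others in the source may bear on it.

Measured compounds:
compound 1 `COc1ccccc1N1CCN(CCC(Oc2ccc(C(=O)Nc3ccccc3OCCCC(=O)O)cc2)c2cccc(C)c2)CC1` — 251 nM
compound 2 `COc1ccccc1N1CCN(CCC(Oc2ccc(C(=O)Nc3ccccc3OCCCC(=O)O)cc2)c2ccc(CC(C)C)cc2)CC1` — 2000 nM
compound 3 `COc1ccc(C(CCN2CCN(c3ccccc3OC)CC2)Oc2ccc(C(=O)Nc3ccccc3OCCCC(=O)O)cc2)cc1` — 200 nM

All three share one core and differ only in the aromatic ring attached to the chain carbon that carries the ether oxygen. In an assay on Prostate gland (Oryctolagus cuniculus) for inhibition of Adrenergic receptor alpha-1 (Homo sapiens) (on this read-out higher numbers stand for weaker binding and lower numbers for tighter binding), compound 3 gives 200 nM, the lowest of the three numbers, but the step of a 1.3-fold lower number from compound 1 to compound 3 (0.10 log units; within the scatter) lies within the scatter, so compound 3 and compound 1 cannot be ranked against each other. Compound 2 stands apart: the step of a 10-fold lower number from compound 2 to compound 3 (1.00 log units; beyond the scatter) and the step of an 8.0-fold higher number from compound 1 to compound 2 (0.90 log units; beyond the scatter) are both beyond the scatter.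

Compound 4 `COc1ccccc1N1CCN(CCC(Oc2ccc(C(=O)Nc3ccccc3OCCCC(=O)O)cc2)c2ccc(Br)cc2)CC1` has not been measured. Its change from compound 3 is bromo in place of methoxy on an aromatic carbon. For the measured compounds named here, two steps bear on it: the exchange of a methoxy for a methyl placed elsewhere on the ring changed little, whereas the exchange of methoxy for the larger isobutyl weakened binding. Bromo is a single heavy atom, smaller than isobutyl, so compound 4 is expected to land near compound 3 in this assay, with a 1.6-fold higher number from compound 3 to compound 4 (0.20 log units; within the scatter) as the estimated step. The estimate for compound 4 is 320 nM, with a range from 100 nM to 1000 nM.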

Compound 4, dissociation constant: 100 nM
Compound 4: the middle estimate sits 3.2-fold (0.51 log units) above what was measured, and the stated range covers the measured number.
By their numbers in this assay, from the lowest: compounds 4, 3 and 1 (each within the scatter of the next, the first and the last beyond it); then compound 2.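

In this assay, the change from 4-methoxyphenyl to 4-bromophenyl shows that this place on the ring accepts a group with a single heavy atom and no hydrogen-bond acceptor, and compound 3 and compound 4 cannot be ranked against each other (a 2.0-fold lower number from compound 3 to compound 4 (0.30 log units; within the scatter)). Compound 4 does separate from compound 1, which compound 3 did not (a 2.5-fold lower number from compound 1 to compound 4 (0.40 log units; beyond the scatter)), and its large gap to the 4-isobutylphenyl compound (a 20-fold lower number from compound 2 to compound 4 (1.30 log units; beyond the scatter)) leaves compound 2 alone as the weakest binder of the four. Nothing measured here explains why bromo and methoxy read alike or why isobutyl differs from both.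

As far as these compounds go, how an amine, a fluoro or a nitrile would read at this same place stays open. So does how an ethyl or propyl chain there would compare with isobutyl.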